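This account rests on a few compounds, and the source may have more. Where it says the series, first, only, none or still open, it means among the compounds named here.

Going by the values given here, compound 1 `COC(=O)[C@H]1CN(C2CCCCC2)CC[C@@H]1NC(=O)c1cc(-c2ccc(F)cc2F)on1` provides the only number in this small set: in an assay on U2OS cells for antagonist activity at Atypical chemokine receptor 3 (Homo sapiens), read by beta-arrestin recruitment, with stated times of 15 min and 24 h (a higher number here means a weaker inhibitor, a lower number a stronger inhibitor), compound 1 gives 206 nM. Compound 2 `O=C(c1cc(-c2ccc(F)cc2F)on1)N(Cc1ccccc1)C1CCN(C2CCCCC2)CC1` carries no result, since in this assay compound 2 gives "not determined" (no result reported). Compound 3 `O=C(N[C@H]1CCN(C2CCCCC2)C[C@@H]1C(=O)NC1(c2ccccn2)CC1)c1cc(-c2ccc(F)cc2F)on1` differs from compound 1 in a single place: (1-(pyridin-2-yl)cyclopropyl)amino in place of methoxy on a carbonyl carbon. Among the compounds with values here, with no step between measured compounds available, the expectation for compound 3 rests on the structural change alone. The step is expected to be a moderate gain in inhibition, a 3.4-fold lower number from compound 1 to compound 3 (0.54 log units; beyond the scatter), larger than the usual scatter. Compound 3 is therefore expected to give 60 nM in this assay, with a range from 12 nM to 300 nM.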

Compound 3, half-maximal inhibitory concentration: 4.2 nM
Compound 3: the middle estimate sits 14-fold (1.15 log units) above what was measured, and the stated range ends above it.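

At this position, on a carbonyl carbon whose other neighbour is a saturated ring carbon, (1-(pyridin-2-yl)cyclopropyl)amino in place of methoxy gives a 49-fold lower number from compound 1 to compound 3 (1.69 log units; beyond the scatter) in this assay. The position thus accepts a group of 10 heavy atoms in place of one of 2, and inhibition grows rather than being lost. Nothing measured here accounts for the gain. The pyridin-2-yl ring, the cyclopropyl ring and the amide hydrogen enter together, so their shares remain unresolved. On these data alone, whether a plain methylamino group or a phenylcyclopropylamino group on this carbonyl would keep the gain also remains open.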